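Swapping the Cyclohexyl Group for a Cyclopentyloxy Group

The compounds below may be only part of what the source reports. "The series", "measured", "known", "first", "only" and "open" are said of these compounds alone.

Two members of this series have been tested in a functional assay on MCF7 cells (Homo sapiens) for inhibition, read by sulforhodamine B assay, with a stated time of 48 h; a lower number here means a stronger inhibitor of growth, a higher number a weaker inhibitor of growth. Compound 1, `c1cc2c(cc1NC1=NCCO1)CCC2`, gives 9100 nM in this assay. Compound 2, `c1cc(C2CCCCC2)ccc1NC1=NCCO1`, gives 17500 nM in this assay. Compound 2 has the higher of the two numbers, yet the gap to compound 1 lies within the usual scatter of repeated measurements, so the two cannot be told apart and neither can be called the weaker inhibitor.

Compound 3, `c1cc(OC2CCCC2)ccc1NC1=NCCO1`, has not yet been measured. It differs from compound 2 in one place: cyclopentyloxy in place of cyclohexyl on an aromatic carbon. The shared core and the rest of the molecule are unchanged.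

Within the data shown here, with no measured pair showing what such a change does, the step of a 1.2-fold lower number from compound 2 to compound 3 (0.07 log units; within the scatter) is expected to stay within the scatter, in no definite direction. Compound 3 is therefore estimated to give 15000 nM in this assay, with a range from 6000 nM to 40000 nM.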

Compound 3, concentration for 50% growth inhibition: 23100 nM
The estimate for compound 3 lay 1.5-fold (0.19 log units) below the measured number; low and high end bracket the measured number.
By their numbers in this assay, from the lowest: compounds 1, 2 and 3 (each within the scatter of the next, the first and the last beyond it).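

In this assay, cyclopentyloxy in place of cyclohexyl on an aromatic carbon gives a 1.3-fold higher number from compound 2 to compound 3 (0.12 log units; within the scatter) and so the two groups cannot be told apart. Among these compounds, this is the first pair that differs in one place, and it shows that this swap, which brings in an oxygen and a hydrogen-bond acceptor and turns the six-membered ring into a five-membered one, has no effect this assay can resolve. No measurement here bears on the reason for this result.

One pair cannot show whether other groups on this carbon would behave the same way. An amine, a carboxylic acid or a longer carbon chain in place of the cyclohexyl group might move the number beyond the scatter or leave it unresolved, and the compounds shown do not tell which.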